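Swapping Fluoro for Trifluoromethyl on the Benzyl Ring

The source may hold more compounds than are shown below. What is called first, only, known or untested is meant among the compounds shown, and "the series" means these compounds.

Of the compounds shown here, three sharing one core have been tested in an in vitro assay on HEK293 cells for displacement of a labelled ligand from adenosine receptor A2b (Homo sapiens); a higher number here means a weaker inhibitor, a lower number a stronger inhibitor. Compound 1 `CC(C)Cn1c(=O)c2nc(-c3cnn(Cc4cccc(F)c4)c3)[nH]c2n(CC(C)C)c1=O` gives 990 nM in this assay, the highest of the three numbers and therefore the weakest binder among them. Compound 2 `CCCn1c(=O)c2nc(-c3cnn(Cc4cccc(Cl)c4)c3)[nH]c2n(CCC)c1=O` gives 18 nM and compound 3 `CCCn1c(=O)c2nc(-c3cnn(Cc4ccccc4OC)c3)[nH]c2n(CCC)c1=O` gives 37 nM. Among the measured compounds shown here, the only single-point step measured, a 2.1-fold higher number from compound 2 to compound 3 (0.31 log units; beyond the scatter), concerns a different part of the molecule and a different pair of groups, so it does not speak directly to the change at hand. Compound 4 `CC(C)Cn1c(=O)c2nc(-c3cnn(Cc4cccc(C(F)(F)F)c4)c3)[nH]c2n(CC(C)C)c1=O` is the next compound, differing from compound 1 by trifluoromethyl in place of fluoro on an aromatic carbon. For the measured compounds named here, nothing measured so far tracks a fluoro-to-trifluoromethyl swap, and compounds 2 and 3 differ from compound 1 in more than one place, so their values cannot be read as a step. Without a guiding step, a change no larger than the scatter is expected, a 1.2-fold lower number from compound 1 to compound 4 (0.09 log units; within the scatter), and compound 4 is estimated at 800 nM in this assay, within 250 nM to 2500 nM.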

Compound 4, inhibition constant: 300 nM
Compound 4: the middle estimate sits 2.7-fold (0.43 log units) above what was measured; measured number inside the range.
By their numbers in this assay, from the lowest: compound 2; then compound 3; then compound 4; then compound 1.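

In this assay, among the compounds shown here, going from 3-fluorobenzyl to 3-(trifluoromethyl)benzyl brings a 3.3-fold lower number from compound 1 to compound 4 (0.52 log units; beyond the scatter) and so gives the first direct reading at this carbon of the benzyl ring, with the rest of the molecule held fixed. The step is modest but beyond the scatter, so what sits at this carbon does matter, and exchanging one heavy atom for four goes with stronger binding rather than weaker. Why the number falls cannot be said, as nothing measured here bears on the cause.

Still open, going by these compounds, is whether a nitrile or an amine at this same carbon would move the number in the same direction or the opposite one. On these data alone, it also remains unknown whether the same swap would give a similar step on the propyl chains that compound 2 carries.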